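Methyl on the Core: Cytotoxicity Expectation for Compound 4

A few compounds are considered here, and "the series" means these few. Any claim that something is new, unique, unknown or untested is made for them only; others in the source may bear on it.

Compound 1 `Cc1cc(C)cc(C(=O)c2cc(Cl)ccc2Oc2ccnc(Nc3ccc(C#N)cc3)n2)c1` gives 28800 nM in an ADME assay on MT4 cells (Homo sapiens) for cytotoxicity, read by MTT assay, with a stated time of 5 days; on this read-out higher numbers stand for lower toxicity in this test and lower numbers for higher toxicity in this test.
Compound 2 `Cc1ccccc1C(=O)c1cc(Cl)ccc1Oc1ccnc(Nc2ccc(C#N)cc2)n1` gives 28800 nM in this assay.
Compound 3 `COc1ccc(C(=O)c2ccccc2)c(Oc2ccnc(Nc3ccc(C#N)cc3)n2)c1` gives 760 nM in this assay.

Compound 2 stands level with compound 1 at the digits shown; together they hold the highest numbers of the three, and compound 3 sits well below both. Going by the values given here, the only single-place step measured is no change at the digits printed from compound 1 to compound 2 (within the scatter), a swap on the carbonyl carbon that left the read-out unmoved. Compound 4 `Cc1cc(Oc2ccc(Cl)cc2C(=O)c2ccccc2C)nc(Nc2ccc(C#N)cc2)n1` differs from compound 2 by methyl in place of hydrogen on an aromatic carbon. Among the compounds with values here, no measured step touches this part of the shared core. The step from compound 1 to compound 2 bears on it only in showing that a small change at the edge of the molecule passed without effect; compound 3 differs from compound 2 in several places at once and cannot be read as a single step. Compound 4 is therefore expected to move little, a 1.2-fold lower number from compound 2 to compound 4 (0.06 log units; within the scatter), a step within the scatter. Compound 4 is estimated at 25000 nM, within 8000 nM to 60000 nM.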

Compound 4, half-maximal cytotoxic concentration: 4240 nM
For compound 4 the middle estimate is 5.9-fold (0.77 log units) above the measured one; the measured number lies below the stated range.
By their numbers in this assay, from the lowest: compound 3; then compound 4; then compounds 1 and 2 (each within the scatter of the next).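

Methyl in place of hydrogen on this aromatic carbon, next to the ring nitrogen, gives a 6.8-fold lower number from compound 2 to compound 4 (0.83 log units; beyond the scatter) in this assay and so shows that this position of the shared core is not silent. The earlier swap on the carbonyl carbon gave no change at the digits printed from compound 1 to compound 2 (within the scatter) and offered no sign of this, whereas here one added carbon shifts the read-out towards higher toxicity in this test. No measurement at hand explains the shift.

The compounds shown leave open whether an ethyl group or an amine on this carbon would lower the number further or restore it. They also leave open whether the same methyl would have a similar effect with the 3,5-dimethylphenyl group of compound 1 on the carbonyl carbon.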